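A few compounds are considered here, and "the series" means these few. Any claim that something is new, unique, unknown or untested is made for them only; others in the source may bear on it.

Measured so far:
Compound 1 `Fc1ccc(NC(=S)Nc2nc3ccccc3s2)cc1` gives 32100 nM in a functional assay on U-937 cells (Homo sapiens) for cytotoxicity, read by MTT assay, with a stated time of 48 h; on this read-out higher numbers stand for weaker inhibition and lower numbers for stronger inhibition.
Compound 2 `Cc1ccc2nc(NC(=S)Nc3ccccc3)sc2c1` reaches the assay limit of > 50000 nM in this assay.

Compound 2 stands at a limit and not at a number, as the limit of > 50000 nM in this assay, at which 1 of the 2 values shown sits, shows. Within the data shown here, compound 1 supplies the only numerical reading among the two. The step from compound 2 leads to compound 3 `Cc1ccc2nc(NC(=S)Nc3ccc(F)cc3)sc2c1`, which carries fluoro in place of hydrogen on an aromatic carbon, para to a large group. Among the measured compounds shown here, no measured pair shares this change, so nothing in the data sets the size of the step in this assay. A step no larger than the scatter is expected, in either direction. Compound 3 is therefore expected near 45000 nM, with a range from 20000 nM to 100000 nM. The expected step is an at least 1.1-fold lower number from compound 2 to compound 3 (0.04 log units; that floor lies within the scatter).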

Compound 3, half-maximal inhibitory concentration: > 50000 nM
Compound 3 gave a limit, no number; the forecaster's own chance of this, stated with the estimate: 55%; middle value at least 1.1-fold (0.04 log units) away from the limit.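

Compound 3 is a limit and not a number, and with compound 2 also at a limit, the fluoro step on the phenyl group cannot be read in this assay. Compound 3 does add a new pair with compound 1, where a methyl group added to the shared core gives an at least 1.5-fold higher number from compound 1 to compound 3 (0.19 log units; that floor lies within the scatter), so this pair does not establish that the methyl changes the reading. The limit now covers most of the compounds shown: the limit of > 50000 nM in this assay, at which 2 of the 3 values shown sit.

Going by these compounds, the size of the fluoro step at this position stays open, as does the real value of compound 3 beyond its limit. The compounds shown also do not tell how a methoxy group or an amine in the place of the fluoro would read in this assay.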